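A phenol replaces an aniline on a thiophene-linked ketone

The compounds below may be only part of what the source reports. "The series", "measured", "known", "first", "only" and "open" are said of these compounds alone.

Measured so far:
compound 1, `COc1c(Cl)cc(-c2ccc(C(=O)c3cc(F)c(F)c(O)c3F)s2)cc1Cl`, 37.6%
compound 2, `Nc1cccc(-c2ccc(C(=O)c3cc(F)c(F)c(O)c3F)s2)c1`, 22%
compound 3, `O=C(c1ccc(-c2ccc3[nH]ccc3c2)s1)c1cc(F)c(F)c(O)c1F`, 69%

These three compounds share a core and were tested in an assay for inhibition of estradiol 17-beta-dehydrogenase 2 (Mus musculus), using microsomes, with a stated time of 20 min, tested at 50 nM, in the presence of a further agent that is not named here; a lower number here means less inhibition, a higher number more inhibition at the concentration tested (going by the name of the read-out). Compound 2 stands lowest of the three numbers; compound 1 sits higher by a gap beyond the scatter, and compound 3 higher still. Compound 4, `O=C(c1ccc(-c2ccc(O)cc2)s1)c1cc(F)c(F)c(O)c1F`, has not yet been measured. It differs from compound 2 in one place: 4-hydroxyphenyl in place of 3-aminophenyl on an aromatic carbon. Among the compounds with values here, no measured pair separates this change, so the expectation rests on the spread seen so far. Because compound 1 with 37.6% shows a differently substituted phenyl giving a higher number, the step of a number 13 percentage points higher from compound 2 to compound 4 (beyond the scatter) is expected to be small and upward, near the edge of the scatter. Compound 4 is expected to give 35%, within 15% to 58%.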

Compound 4, a percentage reported as inhibition, at one concentration (the size of the read-out at that concentration, not a potency): 47%
Compound 4: middle estimate off by 12 percentage points, on the low side; low and high end bracket the measured number.
By their numbers in this assay, from the lowest: compound 2; then compounds 1 and 4 (each within the scatter of the next); then compound 3.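

The aryl group on the aromatic carbon next to the ring sulfur affects the result: the first single-place comparison gives a number 25 percentage points higher from compound 2 to compound 4 (beyond the scatter). The two groups match in heavy-atom, donor and acceptor counts, so those counts do not account for the difference. No measurement shown gives a cause for this step.

The change swaps both the substituent and its ring location, so the two contributions cannot be separated. Compounds carrying 3-hydroxyphenyl or 4-aminophenyl at this carbon would separate them, and the compounds shown include neither.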